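The compounds below may be only part of what the source reports. "The series", "measured", "known", "first", "only" and "open" are said of these compounds alone.

Measured compounds and their results:

- compound 1 `COc1ccc2[nH]c(C(=O)N3CC(=O)N(Cc4ccccc4)[C@@H](N4[C@H](C)CCC[C@@H]4C)C3)cc2c1`: 1400 nM
- compound 2 `COc1ccc2[nH]c(C(=O)N3CC(=O)N(Cc4ccccc4)[C@@H](N4CCc5ccccc54)C3)cc2c1`: > 100000 nM
- compound 3 `COc1ccc2[nH]c(C(=O)N3CC(=O)N(Cc4ccccc4)[C@@H](CN4CCC(C(C)C)CC4)C3)cc2c1`: 3800 nM

These three compounds share one core and differ only in the group attached to a saturated ring carbon. They were tested in an ADME assay on Vero cells (Chlorocebus sabaeus) for cytotoxicity, with a stated time of 7 days; a higher number here means that more compound is tolerated, a lower number that less compound is tolerated. For compound 2 the outcome is the limit of > 100000 nM in this assay, at which 1 of the 3 values shown sits, and not a number. Among the two numbers, compound 3 stands highest, and its nearest neighbour is compound 1, with a 2.7-fold higher number from compound 1 to compound 3 (0.43 log units; beyond the scatter). The other steps were large: an at least 71-fold higher number from compound 1 to compound 2 (1.85 log units; beyond the scatter) and an at least 26-fold lower number from compound 2 to compound 3 (1.42 log units; beyond the scatter).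

Compound 4 `COc1ccc2[nH]c(C(=O)N3CC(=O)N(Cc4ccccc4)[C@@H](CN4CCC5(CCCC5)CC4)C3)cc2c1` is the next compound to be measured in this assay. Compared with compound 3 it carries a group of 10 heavy atoms (9 carbon, 1 nitrogen; one five-membered non-aromatic ring of carbon only, one six-membered non-aromatic ring with 1 hetero atom) in place of a group of 9 heavy atoms (8 carbon, 1 nitrogen; one six-membered non-aromatic ring with 1 hetero atom), on a saturated chain carbon bound to a saturated ring carbon. The measured steps all swap the whole group on the saturated ring carbon, whereas this change keeps that attachment and alters only the outer part of the group. The smallest measured step, from compound 1 to compound 3, is the closest guide, and even that involved a larger change than this one. A step of at most modest size is therefore expected, in either direction. The expected result for compound 4 is 5000 nM, with a range from 1500 nM to 20000 nM, which would mean a 1.3-fold higher number from compound 3 to compound 4 (0.12 log units; within the scatter).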

Compound 4, half-maximal cytotoxic concentration: 3600 nM
For compound 4 the middle estimate is 1.4-fold (0.14 log units) above the measured one; the measured number falls inside the stated range.
By their numbers in this assay, from the lowest: compound 1; then compounds 4 and 3 (each within the scatter of the next). At a limit, above all of these: compound 2.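

In this assay, the step from the 4-isopropylpiperidin-1-yl group to the group with the added five-membered carbon ring is a 1.1-fold lower number from compound 3 to compound 4 (0.02 log units; within the scatter), so on a saturated chain carbon bound to a saturated ring carbon, this alteration of the outer part of the group leaves compound 3 and compound 4 indistinguishable. Compound 4 also stands apart from the two compounds whose groups sit directly on the saturated ring carbon: one comparison gives a 2.6-fold higher number from compound 1 to compound 4 (0.41 log units; beyond the scatter), and the other gives an at least 27-fold lower number from compound 2 to compound 4 (1.44 log units; beyond the scatter), so compound 4 adds a second case, after compound 3, that lies in the same direction from each of them. The figure for compound 2 in that last step is a limit and not a number: the limit of > 100000 nM in this assay, at which 1 of the 4 values shown sits.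

Going by these compounds, it remains open whether the same tolerance would hold if the outer part of the group carried a carboxylic acid or a second amine rather than only carbon. Also open, on these data alone, is how 2,3-dihydro-1H-indol-1-yl would behave on the saturated chain carbon, which would show whether the result for compound 2 follows that group or its direct attachment to the saturated ring carbon.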